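The compounds below may be only part of what the source reports. "The series", "measured", "known", "first", "only" and "open" are said of these compounds alone.

Of the compounds shown here, two from one series have been tested in a functional assay on cells (Leukemia cell, Homo sapiens) for cytotoxicity, read by sulforhodamine B assay, with a stated time of 48 h; on this read-out lower numbers stand for stronger inhibition of growth and higher numbers for weaker inhibition of growth. Compound 1 `Oc1ccc(O)c(-c2cc(-c3ccc(Cl)cc3)nn2-c2ccccc2)c1` carries a 4-chlorophenyl group and an unsubstituted phenyl on the shared core; in this assay compound 1 gives 49700 nM. Compound 2 `CC(=O)NS(=O)(=O)c1ccc(-n2nc(-c3ccccc3)cc2-c2cc(O)ccc2O)cc1` instead carries an acetylsulfonamide-bearing phenyl and a plain phenyl; in this assay compound 2 gives 100000 nM. The numbers of compound 2 and compound 1 lie within the usual scatter of each other, so neither can be called the stronger growth inhibitor on the evidence so far, and compound 2 simply sits at the upper end of the two figures.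

Compound 3 `CC(=O)NS(=O)(=O)c1ccc(-n2nc(-c3ccc(Cl)cc3)cc2-c2cc(O)ccc2O)cc1` is still to be measured. It differs from compound 2 in one spot: chloro in place of hydrogen on an aromatic carbon. Going by the values given here, no measured pair in this set isolates that change, so its effect can only be estimated. Compound 3 is expected to show a step of a 1.7-fold lower number from compound 2 to compound 3 (0.22 log units; within the scatter), a modest move towards stronger inhibition that may not exceed the scatter. Compound 3 is therefore estimated at 60000 nM, within a range of 25000 nM to 130000 nM.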

Compound 3, concentration for total growth inhibition: 92600 nM
For compound 3 the middle estimate is 1.5-fold (0.19 log units) below the measured one, and the stated range covers the measured number.
By their numbers in this assay, from the lowest: compounds 1, 3 and 2 (each within the scatter of the next).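

Chloro in place of hydrogen on an aromatic carbon, para to a large group, can now be read directly in this assay: the phenyl to 4-chlorophenyl change gives a 1.1-fold lower number from compound 2 to compound 3 (0.03 log units; within the scatter), which lies within the scatter, so this single atom makes no change that can be told apart in this assay. Going by these compounds alone, a second single change can also be read for the first time: gaining the acetylsulfamoyl group gives a 1.9-fold higher number from compound 1 to compound 3 (0.27 log units; within the scatter), and this step also lies within the scatter. No measured evidence bears on either of these two results.

The compounds shown leave open whether a different group at the chloro position, such as an amine, a methoxy group or a carboxylic acid, would give a step beyond the scatter in this assay. They also leave open whether a plain sulfonamide or a longer acyl chain in place of the acetylsulfamoyl group would move the number any further than the acetylsulfamoyl group does.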